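Swapping one ring on the sulfonyl sulfur

The source may report more compounds than this note shows. Statements on the series, on what has been measured and on what is new or still open speak of the compounds shown alone.

Measured so far in a physicochemical assay for solubility, in phosphate buffer, with a stated time of 24 h, at pH 7.4, tested at 100 uM; on this read-out higher numbers stand for higher solubility and lower numbers for lower solubility
Compound 1 `O=C(NCc1ccc(S(=O)(=O)c2cccc(C(F)(F)F)c2)cc1)N1Cc2ccncc2C1` gives 10000 nM
Compound 2 `O=C(NCc1ccc(S(=O)(=O)N2CCOCC2)cc1)N1Cc2ccncc2C1` gives 59000 nM

Of these two, compound 2 holds the higher number, and the gap to compound 1 lies beyond the usual scatter. Compound 3 `CN1CCN(S(=O)(=O)c2ccc(CNC(=O)N3Cc4ccncc4C3)cc2)CC1` keeps the rest of compound 2 and puts 4-methylpiperazin-1-yl in place of morpholin-4-yl on a sulfonyl sulfur. One measured step acts at that same place (a 5.9-fold higher number from compound 1 to compound 2 (0.77 log units; beyond the scatter)), and it was modest. That step exchanged 3-(trifluoromethyl)phenyl for morpholin-4-yl, whereas the new change exchanges one six-membered non-aromatic ring with 2 hetero atoms for another, so it offers only a loose guide. In this assay no step beyond the scatter is therefore expected, and the estimated step is small (a 1.1-fold higher number from compound 2 to compound 3 (0.04 log units; within the scatter)). For compound 3 the expected value is 65000 nM, with an estimated range from 35000 nM to 100000 nM at its ends.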

Compound 3, solubility: 160000 nM
Beside the measured number, compound 3's estimate is 2.5-fold (0.39 log units) below it; the whole stated range lies below it.
By their numbers in this assay, from the lowest: compound 1; then compound 2; then compound 3.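

In this assay, the place on the sulfonyl sulfur still responds when one six-membered non-aromatic ring with 2 hetero atoms replaces another, giving a 2.7-fold higher number from compound 2 to compound 3 (0.43 log units; beyond the scatter), so an exchange within the same ring type can also move the number. Replacing the 3-(trifluoromethyl)phenyl group gives a still wider spread, with a 16-fold higher number from compound 1 to compound 3 (1.20 log units; beyond the scatter), and the order from lowest to highest number runs 3-(trifluoromethyl)phenyl, morpholin-4-yl, 4-methylpiperazin-1-yl. No supporting measurement explains why 4-methylpiperazin-1-yl stands highest.

Going by these compounds, it remains open whether the ring alone or its methyl group carries this step, a question that piperazin-1-yl, the same ring without the methyl, would address. Where an open-chain dimethylamino group would fall in this order on the same sulfur also remains unknown.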